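This account rests on a few compounds, and the source may have more. Where it says the series, first, only, none or still open, it means among the compounds named here.

Measured compounds in an ADME assay on HUVEC cells (Homo sapiens) for antiproliferative activity, read by MTT assay, with a stated time of 48 h; on this read-out lower numbers stand for stronger inhibition and higher numbers for weaker inhibition:
- Compound 1 `Cc1ccc(-n2nncc2CN2C(=O)C3(C(C#N)=C(N)Oc4c3c3nc5ccccc5nc3c3ccccc43)c3ccccc32)cc1C`: in this assay compound 1 gives > 50000 nM, which is a limit of the assay.
- Compound 2 `Cc1ccc(-n2nncc2CN2C(=O)C3(C(C#N)=C(N)Oc4c3c3nc5ccccc5nc3c3ccccc43)c3ccccc32)cc1Cl`: in this assay compound 2 gives > 50000 nM, also a limit.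
- Compound 3 `N#CC1=C(N)Oc2c(N)cc3nc4ccccc4nc3c2C12C(=O)N(Cc1cnnn1-c1cccc(C(F)(F)F)c1)c1ccccc12`: in this assay compound 3 gives > 50000 nM, again a limit.

Compound 3 therefore stands at the limit, as do the other two, because of the limit of > 50000 nM in this assay, at which 3 of the 3 values shown sit. Going by the values given here, the only step between measured compounds, a step that the two limits leave unreadable from compound 1 to compound 2, is unreadable from the two limits and concerns a different place.

Compound 4 `CCc1cccc(CC)c1-n1nncc1CN1C(=O)C2(C(C#N)=C(N)Oc3c(N)cc4nc5ccccc5nc4c32)c2ccccc21` differs from compound 3 by 2,6-diethylphenyl in place of 3-(trifluoromethyl)phenyl on an aromatic nitrogen. No measured step touches this aromatic nitrogen, so nothing shown sets a size or direction for this change. The expected step is a number no higher from compound 3 to compound 4 (the limit leaves the size open). Compound 4 is therefore expected to stay at the limit, estimated as 50000 nM with range 15000 nM to 200000 nM.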

Compound 4, half-maximal inhibitory concentration: > 50000 nM
Compound 4: a limit, no number; the forecaster's own chance of this, stated with the estimate: 80%; the middle value lies on the limit itself.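

No step can be read from compound 3 to compound 4 in this assay: both values are limits, not numbers. The compounds shown leave open whether any change to the shared core or its aromatic substituents shifts the read-out, with all of them at one bound: the limit of > 50000 nM in this assay, at which 4 of the 4 values shown sit.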